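A few compounds are considered here, and "the series" means these few. Any claim that something is new, unique, unknown or untested is made for them only; others in the source may bear on it.

Working notes on a small set of chromone-type compounds assessed in an in vitro assay on BTI-TN-5B1-4 cells for inhibition of Amine oxidase [flavin-containing] A (Homo sapiens), tested at 100 uM; a lower number here means less inhibition, a higher number more inhibition at the concentration tested (going by the name of the read-out).

Compound 1 `COc1ccc(-c2cc(=O)c3ccc(F)cc3o2)cc1` gives 40% in this assay. Compound 2 `Cc1ccc(-c2cc(=O)c3ccc(C)cc3o2)cc1` gives 40%. Compound 3 `COc1ccc(-c2cc(=O)c3ccc(C)cc3o2)cc1` gives 40%. The three values stand level with one another within the usual scatter, so no ordering among them is claimed.

Two single-point changes connect the measured compounds. From compound 3 to compound 1 the change is fluoro in place of methyl on an aromatic carbon; the measured step, no change at the digits printed from compound 3 to compound 1 (within the scatter), lies within the scatter. The other connection is the step of no change at the digits printed from compound 2 to compound 3 (within the scatter), also within the scatter.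

Compound 4 `Cc1ccc(-c2cc(=O)c3ccc(F)cc3o2)cc1` has not yet been measured. It differs from compound 2 by fluoro in place of methyl on an aromatic carbon, the same change that carries compound 3 to compound 1. The two places are described word for word alike, so this is the same change, made here on the core of compound 2 rather than that of compound 3. The two cores differ from each other by methyl in place of methoxy on an aromatic carbon.

Since the earlier instance of this change gave no change at the digits printed from compound 3 to compound 1 (within the scatter), the expected step for compound 4 is of the same size, no change at the digits printed from compound 2 to compound 4 (within the scatter). Compound 4 is therefore estimated at 40% in this assay, with a range from 30% to 50%. This expectation rests on a single prior instance of the change and on three values that all sit at one level, so it is weakly founded.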

Compound 4, a percentage reported as inhibition, at one concentration (the size of the read-out at that concentration, not a potency): "not active" (no number reported)
No number was reported for compound 4, and the estimate cannot be compared.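

Within the data shown here, compound 4 carries no number in this assay, so no step from compound 2 to compound 4 can be read, nor any step linking compound 4 to compound 1. The compounds shown leave open whether fluoro in place of methyl on the core of compound 2 matches the step seen on the core of compound 3. No supporting data shown bear on this result.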